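Benzyloxycarbonyl for Acetyl: What Compound 3 Might Give

A few compounds are considered here, and "the series" means these few. Any claim that something is new, unique, unknown or untested is made for them only; others in the source may bear on it.

Compound 1 `COc1cc2nc(N3CCN(C(C)=O)[C@@H]4CCCC[C@@H]43)nc(N)c2cc1OC` is the tighter-binding of the two measured compounds in a functional assay (strain Wistar) for antagonist activity at Alpha-1B adrenergic receptor (Rattus norvegicus), with a stated time of 30 min, in the presence of a further agent that is not named here; on this read-out higher numbers stand for weaker binding and lower numbers for tighter binding; in that assay compound 1 gives 0.617 nM. Its mirror image, compound 2 `COc1cc2nc(N3CCN(C(C)=O)[C@H]4CCCC[C@H]43)nc(N)c2cc1OC`, gives in this assay a value of 3.02 nM, and the step of a 4.9-fold higher number from compound 1 to compound 2 (0.69 log units; beyond the scatter) is attributed to the fact that compounds 1 and 2 differ only in the configuration as drawn. Compound 1 therefore stands at the lowest number of the pair.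

Compound 3 `COc1cc2nc(N3CCN(C(=O)OCc4ccccc4)[C@@H]4CCCC[C@@H]43)nc(N)c2cc1OC` differs from compound 1 by benzyloxy in place of methyl on a carbonyl carbon, that is, acetyl to benzyloxycarbonyl. Going by the values given here, no measured step touches this position: the single step in hand, a 4.9-fold higher number from compound 1 to compound 2 (0.69 log units; beyond the scatter), concerns configuration only and leaves the acyl group unchanged, so it offers no guide to the size or direction of a change at the carbonyl carbon. The expectation for compound 3 in this assay thus rests on compound 1 alone, with wide uncertainty in both directions and a modest shift toward a higher number considered most likely. Compound 3 is expected to give 1.5 nM, with a range from 0.3 nM to 8 nM. This corresponds to an expected step of a 2.4-fold higher number from compound 1 to compound 3 (0.39 log units; beyond the scatter).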

Compound 3, dissociation constant: 1.82 nM
Compound 3: middle estimate off by 1.2-fold (0.08 log units), on the low side; measured number inside the range.
By their numbers in this assay, from the lowest: compound 1; then compounds 3 and 2 (each within the scatter of the next).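

In this assay, the change at this carbonyl carbon registers as a real but limited shift: benzyloxy in place of methyl gives a 2.9-fold higher number from compound 1 to compound 3 (0.47 log units; beyond the scatter). The position therefore takes a far larger group, with 8 heavy atoms and a six-membered aromatic ring of carbon only in place of 1 heavy atom, at the cost of a modest step rather than a loss of the read-out, and compound 3 still gives 1.82 nM. Going by these compounds alone, nothing in hand offers a reason for this step, as the only information available concerns configuration and does not touch the acyl group.

The compounds shown leave open which part of the entering group accounts for the step, the oxygen on the carbonyl carbon or the aromatic ring, and a methoxy or a benzyl group at the same carbon would separate the two. They also leave open whether the gap between the mirror images, a 4.9-fold higher number from compound 1 to compound 2 (0.69 log units; beyond the scatter), persists when benzyloxycarbonyl replaces acetyl, and how an amine or a longer alkyl chain on this carbonyl carbon would read in this assay.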